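Shortening the Piperazine Substituent in a Dienamide Series

A few compounds are considered here, and "the series" means these few. Any claim that something is new, unique, unknown or untested is made for them only; others in the source may bear on it.

Of the compounds shown here, three sharing a hydroxy-dienamide core have been measured in a functional assay on IMR-32 cells (Homo sapiens) for antiproliferative activity, read by sulforhodamine B assay, with a stated time of 48 h; on this read-out lower numbers stand for stronger inhibition and higher numbers for weaker inhibition. Compound 1, `CCN1CCN(C(=O)/C=C/C=C/[C@H](O)Cc2ccc(OC)c(OC)c2)CC1`, carries a 4-ethylpiperazin-1-yl amide and gives 10800 nM. Compound 2, `COc1ccc(C[C@@H](O)/C=C/C=C/C(=O)N2CCN(C(c3ccccc3)c3ccccc3)CC2)cc1OC`, gives 11900 nM, and compound 3, `COc1ccc(C[C@@H](O)/C=C/C=C/C(=O)NCc2cc(OC)c(OC)c(OC)c2)cc1OC`, gives 13400 nM. The three numbers sit close together: the gap between compound 1 and either of the others lies within the usual scatter of repeated measurements, so none of them can be set apart from the rest on these data.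

Compound 4, `COc1ccc(C[C@@H](O)/C=C/C=C/C(=O)N2CCN(C)CC2)cc1OC`, is not yet measured. It differs from compound 1 in a single place: hydrogen in place of methyl on a saturated chain carbon bound to an amine nitrogen in a ring. Among the measured compounds shown here, no pair of measured compounds differs in just one place, so there is no measured step to lean on. Compounds 2 and 3, which carry quite different amide groups, give numbers within the scatter of compound 1, and the removal of a single carbon from the ethyl group is a smaller change than either of those. For this reason the step of a 1.0-fold higher number from compound 1 to compound 4 (0.01 log units; within the scatter) is expected to be none beyond the scatter. Compound 4 is therefore estimated at 11000 nM, with a plausible range from 5000 nM to 25000 nM.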

Compound 4, half-maximal inhibitory concentration: 18900 nM
Beside the measured number, compound 4's estimate is 1.7-fold (0.24 log units) below it; the range from low to high includes it.
By their numbers in this assay, from the lowest: compounds 1, 2, 3 and 4 (each within the scatter of the next).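

In this assay, this position now has its first measured step in the series, and swapping 4-ethylpiperazin-1-yl for 4-methylpiperazin-1-yl gives a 1.8-fold higher number from compound 1 to compound 4 (0.24 log units; within the scatter). The earlier compounds could not show this, as no two of them formed a listed one-place pair, so they said nothing directly about this saturated chain carbon bound to an amine nitrogen in a ring. On this single pair, hydrogen in place of methyl at that carbon cannot be told apart from repeat-measurement scatter, so shortening ethyl to methyl has no demonstrated effect on the read-out, and no measurement shown here offers any explanation of the numbers.

The compounds shown leave open whether this position stays just as undemanding when the group placed there is very different, as one pair of small alkyl groups covers only a narrow range of possible changes. A longer chain such as propyl, or a chain ending in a carboxylic acid, in place of the ethyl group would test whether the numbers stay within the scatter of compound 1 or move clearly away from it.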